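The source may report more compounds than this note shows. Statements on the series, on what has been measured and on what is new or still open speak of the compounds shown alone.

Compound 1 `CCCC(=O)OCSc1ccccc1C(=O)NCCCCNC(C)=O` in an ADME assay on CEM-SS cells (Homo sapiens) for cytotoxicity, read by XTT assay, with a stated time of 6 days (a lower number here means that less compound is tolerated, a higher number that more compound is tolerated), gives 17.4 uM, the lowest of the three numbers in hand. Compound 3 `CCCC(=O)OCSc1ccccc1C(=O)Nc1cccc(C(N)=O)c1` gives 17.5 uM, within the scatter of compound 1, while compound 2 `CCCC(=O)OCSc1ccccc1C(=O)Nc1ccccc1C(N)=O` gives 50.1 uM, a gap from compound 1 that lies beyond the scatter. Compound 4 `CCCC(=O)OCSc1ccccc1C(=O)NC` is not yet measured in this assay. It differs from compound 1 by hydrogen in place of 3-acetamidopropyl on a saturated chain carbon bound to an amide-type nitrogen. Among the compounds with values here, no step between measured compounds that differ in one place is available, so nothing in hand calibrates this change; the three values so far span only a narrow range. The step of a 1.1-fold higher number from compound 1 to compound 4 (0.06 log units; within the scatter) is expected to stay within the scatter, with no clear direction. The estimate for compound 4 is 20 uM, in the range 8 uM to 50 uM.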

Compound 4, half-maximal toxic concentration: 5.7 uM
For compound 4 the middle estimate is 3.5-fold (0.55 log units) above the measured one; the measured number lies below the stated range.
By their numbers in this assay, from the lowest: compound 4; then compounds 1 and 3 (each within the scatter of the next); then compound 2.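

In this assay, within the data shown here, the change from 4-acetamidobutyl to methyl gives a 3.1-fold lower number from compound 1 to compound 4 (0.48 log units; beyond the scatter), the first readable step. This position on the amide-type nitrogen therefore affects the number, and the shorter substituent goes with less compound tolerated. No available evidence gives a cause for this step.

The compounds shown do not separate chain length from the acetamido end. A propyl chain, or a butyl chain ending in an amine or a carboxylic acid, would bear on that question.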